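The source may report more compounds than this note shows. Statements on the series, on what has been measured and on what is new or still open speak of the compounds shown alone.

Working notes on the series.

Compound 1 `O=C(NN1Cc2ccccc2C1)c1cc([N+](=O)[O-])ccc1F`, compound 2 `O=C(NN1Cc2ccccc2C1)c1cc([N+](=O)[O-])ccc1Cl` and compound 3 `O=C(NN(Cc1ccccc1)Cc1ccccc1)c1cc([N+](=O)[O-])ccc1Cl` have been run in an ADME assay on L6 cells (Rattus norvegicus) for cytotoxicity; a lower number here means a stronger inhibitor, a higher number a weaker inhibitor. Compound 2 gives 19800 nM in this assay. Compound 3 gives 41700 nM in this assay. For compound 1 this assay returns only a limit, > 331000 nM, and not a number.

Compound 1 and compound 2 differ in one place: fluoro in place of chloro on an aromatic carbon. That change gave an at least 16-fold higher number from compound 2 to compound 1 (1.22 log units; beyond the scatter), a result set by the limit of > 331000 nM in this assay, at which 1 of the 3 values shown sits. Compound 3 holds the highest of the two numbers recorded, and compound 2 sits nearest to it, with a lower number that is beyond the usual scatter. The difference between the core of compound 2 and the core of compound 3 is not broken down here.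

Compound 4 `O=C(NN(Cc1ccccc1)Cc1ccccc1)c1cc([N+](=O)[O-])ccc1F` is not yet measured in this assay. It differs from compound 3 in one place: fluoro in place of chloro on an aromatic carbon. The place described is word for word that of the change from compound 2 to compound 1, so this is the same change made on the other core.

Taking the step seen from compound 2 to compound 1 as the guide, the step is expected to be a 12-fold higher number from compound 3 to compound 4 (1.08 log units; beyond the scatter), resting on an at least 16-fold higher number from compound 2 to compound 1 (1.22 log units; beyond the scatter) and on compound 3 already giving 41700 nM in this assay. Compound 4 is therefore estimated at 500000 nM in this assay, likely reported only as a limit, with an expected range from 150000 nM to 2000000 nM.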

Compound 4, half-maximal inhibitory concentration: 19300 nM
The estimate for compound 4 lay 26-fold (1.41 log units) above the measured number; the whole stated range lies above it.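

In this assay, fluoro in place of chloro on an aromatic carbon gave a 2.2-fold lower number from compound 3 to compound 4 (0.33 log units; beyond the scatter), so on the core of compound 3 the change runs the opposite way to the earlier step, and the result on one core did not carry over to the other: the same change on two cores in this assay, an at least 16-fold higher number (1.22 log units; beyond the scatter) from compound 2 to compound 1 and a 2.2-fold lower number (0.33 log units; beyond the scatter) from compound 3 to compound 4, at least 36-fold (1.55 log units) apart, beyond the scatter of two such steps

The earlier step is set by the value for compound 1, which is a limit and not a number, so only its smallest possible size is known: the limit of > 331000 nM in this assay, at which 1 of the 4 values shown sits.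

Within these two pairs, the outcome of this change depends on the core it is made on, but the pairs do not show which feature of the core is responsible, and two pairs give no rule for any further core.

What the compounds shown leave open is how a bromo or a methoxy group in the same place would read on the core of compound 2 and on the core of compound 3, and whether such a group would split the two cores as fluoro and chloro do. Also open, going by these compounds, is whether that split would remain if a nitrile or an amine took the place of the nitro group.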